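This account rests on a few compounds, and the source may have more. Where it says the series, first, only, none or still open, it means among the compounds named here.

Compound 1 `COc1ccc(C(=O)Nc2cccc(Cl)c2Cl)cc1OC1CCCC1` — in an assay on isolated protein for inhibition of phosphodiesterase 4A (Sus scrofa) (on this read-out higher numbers stand for weaker inhibition and lower numbers for stronger inhibition), compound 1 gives > 200000 nM, which is a limit of the assay and not a number.
Compound 2 `COc1ccc(C(=O)Nc2c(F)cccc2F)cc1` — in this assay compound 2 gives 37000 nM.
Compound 3 `COc1ccc(C(=O)Nc2ccccc2Cl)cc1OC(=O)C(C)(C)C` — in this assay compound 3 gives > 1000000 nM, again a limit rather than a number.

Compound 1 thus stands only at a limit, as does compound 3, and compound 2 alone yields an actual number. No two of these compounds differ in a single place, so no measured step is available to guide a prediction. Compound 4 `COc1ccc(C(=O)Nc2ccccn2)cc1OC1CCCC1` differs from compound 1 by pyridin-2-yl in place of 2,3-dichlorophenyl on an amide-type nitrogen. Within the data shown here, with no comparable step to draw on, the expected size of the change in this assay is uncertain, though the step from compound 1 to compound 4 is expected to be an at least 3.3-fold lower number from compound 1 to compound 4 (0.52 log units; beyond the scatter), toward stronger inhibition. Compound 4 is estimated at 60000 nM, with a range from 5000 nM to 500000 nM.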

Compound 4, half-maximal inhibitory concentration: 1000 nM
Compound 4: middle estimate off by 60-fold (1.78 log units), on the high side, outside the stated range (below it).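

In this assay, placing pyridin-2-yl instead of 2,3-dichlorophenyl on the amide-type nitrogen gives an at least 200-fold lower number from compound 1 to compound 4 (2.30 log units; beyond the scatter), so this single place has a large effect on the read-out. The value of compound 1 is a limit and not a number: the limit of > 200000 nM in this assay, at which 1 of the 4 values shown sits.

This change brings in a ring nitrogen and removes both chlorines at once, and the compounds shown do not separate these two parts of the change. They also leave open how an unsubstituted phenyl or a pyrimidin-2-yl would behave at this place.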